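The source may report more compounds than this note shows. Statements on the series, on what has been measured and on what is new or still open speak of the compounds shown alone.

Compound 1 `COc1cc(C(=O)O)ccc1Cc1cn(C2CCCC2)c2ccc(NC(=O)OC3CCCC3)cc12` and compound 2 `COc1cc(C(=O)NS(=O)(=O)c2ccccc2Cl)ccc1Cc1nn(C)c2ccc(NC(=O)OC3CCCC3)cc12` share a core but differ in several places at once. In an assay on lung parenchyma (Cavia porcellus) for displacement of a labelled ligand from cysteinyl leukotriene receptor (Homo sapiens) (on this read-out lower numbers stand for stronger inhibition and higher numbers for weaker inhibition), compound 1 gives 53 nM, while compound 2 gives 0.3 nM, the lower of the two numbers shown, and the gap between them lies well beyond the usual scatter. Compound 3 `COc1cc(C(=O)NS(=O)(=O)c2ccccc2C)ccc1Cc1nn(C)c2ccc(NC(=O)OC3CCCC3)cc12` differs from compound 2 only by methyl in place of chloro on an aromatic carbon. Among the measured compounds shown here, with no comparable step measured, the change is expected to be small, as a 1.3-fold higher number from compound 2 to compound 3 (0.12 log units; within the scatter), with no clear direction. Compound 3 is therefore estimated at 0.4 nM, between 0.15 nM and 1.2 nM.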

Compound 3, inhibition constant: 0.3 nM
Estimate against measurement, compound 3: 1.3-fold (0.12 log units) above; the measured number falls inside the stated range.
By their numbers in this assay, from the lowest: compounds 2 and 3 (each within the scatter of the next); then compound 1.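

In this assay, methyl in place of chloro on an aromatic carbon gives no change at the digits printed from compound 2 to compound 3 (within the scatter). Among the compounds shown here, this is the first comparison here that differs in one place, and it shows that, ortho to a large group, 2-chlorophenyl and 2-methylphenyl cannot be told apart on this read-out. Nothing available explains why the two groups read alike. Still open, as far as these compounds go, is whether this carbon would tolerate a methoxy group, an amine or a carboxylic acid equally well. Also open, from the compounds shown here alone, is how a plain phenyl ring without any group there would read.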